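The compounds below may be only part of what the source reports. "The series", "measured", "known", "first", "only" and "open" are said of these compounds alone.

Working notes on the series. The shared core of compound 1 `COC(=O)c1c(Nc2ccc(OC)cc2)sc(C(=O)c2ccc(OC)cc2)c1C` carries an anilino group, a methyl ester and an aryl ketone; in a functional assay, with a stated time of 150 min, tested at 35 ug/mL (a higher number here means a stronger effect of the compound at the concentration tested, a lower number a weaker effect), compound 1 gives 25.1%. Compound 2 `COC(=O)c1c(Nc2ccc(F)cc2)sc(C(=O)c2ccc(OC)cc2)c1C` differs only in the anilino ring, and in this assay compound 2 gives 25.6%. Compound 3 `COC(=O)c1c(Nc2ccc(Cl)cc2)sc(C(=O)c2ccc(OC)cc2)c1C` is reported in this assay as "not active" (no number reported), with no number. Among the compounds with values here, the one step between measured compounds that differ in one place is a number 0.5 percentage points higher from compound 1 to compound 2 (within the scatter), so compound 2 and compound 1 stand together within the usual scatter, and compound 3 gives nothing to compare against.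

Compound 4 `COC(=O)c1c(Nc2ccc(F)cc2)sc(C(=O)c2ccc(C)cc2)c1C` is the next entry. Against compound 2 the change is methyl in place of methoxy on an aromatic carbon, on the aryl ketone side of the core. Within the data shown here, no measured step touches this ring: the only step in hand, fluoro in place of methoxy on the anilino ring, concerns another place and another group, and it was within the scatter anyway. With nothing pointing either way, compound 4 is expected to stay with compound 2, a step of a number 0.6 percentage points lower from compound 2 to compound 4 (within the scatter) that is not expected to exceed the scatter. The estimate for compound 4 in this assay is therefore 25%, with a range from 12% to 38%.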

Compound 4, a percentage reported as activity, at one concentration (the size of the read-out at that concentration, not a potency): "not active" (no number reported)
For compound 4 the study gives words and no number; there is nothing to compare the estimate with.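

Within the data shown here, compound 4 is reported only in words in this assay, so no step from compound 2 to compound 4 can be read. No measured evidence bears on this result. The compounds shown leave open how large the effect of the 4-methoxyphenyl to 4-methylphenyl change is, and how far compound 3 and compound 4 stand from compound 2.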